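The source may report more compounds than this note shows. Statements on the series, on what has been measured and on what is new or still open speak of the compounds shown alone.

Three compounds were tested in a functional assay on the whole organism (strain albino) for inhibition, with Rattus norvegicus as the target, read by paw edema, with stated times of 1 h and 0.5 h, at a dose of 100 mg/kg by the oral route; on this read-out lower numbers stand for less inhibition and higher numbers for more inhibition at the one dose given (going by the name of the read-out). Compound 1 `N#Cc1c(-c2ccccc2)nc(SCC(=O)Nn2c(COc3ccc(Cl)cc3Cl)nc3ccccc3c2=O)[nH]c1=O` gives 80.8% in this assay, compound 2 `N#Cc1c(-c2ccc(Cl)cc2)nc(SCC(=O)Nn2c(COc3ccc(Cl)cc3Cl)nc3ccccc3c2=O)[nH]c1=O` gives 61.5%, and compound 3 `N#Cc1c(Nc2ccccc2)nc(SCC(=O)Nn2c(COc3ccc(Cl)cc3Cl)nc3ccccc3c2=O)nc1-c1ccccc1` gives 71.2%. Compounds 1 and 2 differ by one change, (chloro in place of hydrogen on an aromatic carbon), which made the step of a number 19.3 percentage points lower from compound 1 to compound 2 (beyond the scatter). Compound 3 carries a different core; how its core differs from that of compound 1 is not broken down here. Compound 4 `N#Cc1c(Nc2ccc(Cl)cc2)nc(SCC(=O)Nn2c(COc3ccc(Cl)cc3Cl)nc3ccccc3c2=O)nc1-c1ccccc1` is not yet measured; it differs from compound 3 by chloro in place of hydrogen on an aromatic carbon, the same change that was made from compound 1 to compound 2, at the same kind of place on the ring. Because that change gave the step of a number 19.3 percentage points lower from compound 1 to compound 2 (beyond the scatter), a lowering is expected for compound 4 as well, estimated as a number 15.2 percentage points lower from compound 3 to compound 4 (beyond the scatter). Compound 4 is therefore expected to give about 56% in this assay, with an uncertainty spanning 42% to 70% since the change was seen once on a core that is not the same.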

Compound 4, a percentage reported as inhibition, in the whole organism at one dose (the size of the read-out at that dose, not a potency): 51.9%
Beside the measured number, compound 4's estimate is 4.1 percentage points above it; low and high end bracket the measured number.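

In this assay, chloro in place of hydrogen gave a number 19.3 percentage points lower from compound 3 to compound 4 (beyond the scatter), so the change carried from one core to the other with no difference in size: the same change on two cores in this assay, a number 19.3 percentage points lower (beyond the scatter) from compound 1 to compound 2 and a number 19.3 percentage points lower (beyond the scatter) from compound 3 to compound 4, 0 percentage points apart, within the scatter of two such steps. This shows that in these two pairs the lowering survives the change of core, so the step seen on one core was a fair guide to the other. Among these compounds, it rests on only two pairs, however, and does not show why the number falls or whether the same step would appear on any further core.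

The compounds shown leave open what other groups at that place on the ring would do, such as fluoro, methoxy or an amine.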